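Adding a methoxy group to compound 1

This account rests on a few compounds, and the source may have more. Where it says the series, first, only, none or still open, it means among the compounds named here.

Measured in an ADME assay on RAW264.7 cells (Mus musculus) for cytotoxicity, read by MTT assay; on this read-out lower numbers stand for stronger inhibition and higher numbers for weaker inhibition:
compound 1 `O=C(/C=C/C=C/c1ccccc1)c1ccccc1`: 44300 nM
compound 2 `O=C(/C=C/C=C/c1ccccc1)c1ccccc1O`: "not determined" (no result reported)
compound 3 `O=C(/C=C/C=C/c1ccccc1)c1ccc(Cl)cc1`: "not determined" (no result reported)

Only compound 1 has a number in this assay, namely 44300 nM. No result was reported for compound 2 or compound 3, so there is nothing to rank compound 1 against. Its value can serve only as a starting point, not as a sign of how changes to the shared core play out.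

The next compound to be tested is compound 4 `COc1ccc(/C=C/C=C/C(=O)c2ccccc2)cc1`, which keeps the core of compound 1 and differs from it in one place: methoxy in place of hydrogen on an aromatic carbon. In plain terms, it has methoxy in place of hydrogen on an aromatic carbon, para to a large group.

For the measured compounds named here, no measured pair in this small set shows how far a single change can move the half-maximal inhibitory concentration. The forecast therefore rests on compound 1 at 44300 nM alone. The expectation is a small step with no clear direction, probably none beyond the usual scatter. The estimated change is a 1.1-fold lower number from compound 1 to compound 4 (0.04 log units; within the scatter). For compound 4 the estimated value is 40000 nM, with an expected range of 16000 nM to 90000 nM.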

Compound 4, half-maximal inhibitory concentration: > 100000 nM
Compound 4 gave a limit, no number; the forecaster's own chance of this, stated with the estimate: 15%; middle value at least 2.5-fold (0.39 log units) from the limit.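

In this assay, for the compounds shown here, methoxy in place of hydrogen on an aromatic carbon, para to a large group, gives an at least 2.2-fold higher number from compound 1 to compound 4 (0.35 log units; beyond the scatter) and this is the first single change in the set that can be read. A higher number on this read-out means weaker inhibition, so this one change at this position moves the result in that direction by more than the usual scatter, something compound 1 could not show on its own. The entry for compound 4 is a limit of the assay and not a number, which means the step has a lower bound but no known full size: the limit of > 100000 nM in this assay, at which 1 of the 4 values shown sits.

Going by these compounds, whether other groups at this same place would move the result in the same way remains open, for example an amine, a carboxylic acid or a longer chain such as ethoxy, and one pair cannot say whether the shift belongs to methoxy in particular or would follow from other replacements of that hydrogen. On these data alone, with no result for compound 2 or compound 3, the effect of changes elsewhere on the shared core also remains unknown.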